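The source may hold more compounds than are shown below. What is called first, only, known or untested is meant among the compounds shown, and "the series" means these compounds.

Compound 1 `Nc1ccccc1NC(=O)c1ccc(CSc2cccc(F)c2)cc1`: 46.9%
Compound 2 `Nc1ccccc1NC(=O)c1ccc(CSCCc2ccccc2)cc1`: 44.9%

Both values come from a functional assay on A549 cells (Homo sapiens) for inhibition, read by CCK-8 assay, with a stated time of 72 h, tested at 2 uM; on this read-out higher numbers stand for more inhibition of growth at the one concentration tested and lower numbers for less inhibition of growth. In this assay compound 2, at 44.9%, stands level with compound 1 within the scatter, so the two cannot be ranked.

Compound 3 `Cc1cc(C)cc(SCc2ccc(C(=O)Nc3ccccc3N)cc2)c1` carries 3,5-dimethylphenyl in place of phenethyl on a sulfur.

Going by the values given here, only one measured step bears on this change. It touches the same place on the sulfur: a number 2 percentage points lower from compound 1 to compound 2 (within the scatter), with phenethyl in place of 3-fluorophenyl. Compound 3 again has a phenyl ring on the sulfur, as compound 1 does, and that exchange moved the number by no more than the scatter. No step beyond the scatter is therefore expected, though a single step is thin evidence. The expected change is a number 1.1 percentage points higher from compound 2 to compound 3 (within the scatter). For compound 3 the estimate is 46%, with an expected range of 36% to 57%.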

Compound 3, percent growth inhibition at one concentration: 33.3%
The estimate for compound 3 lay 12.7 percentage points above the measured number; measured number below the stated range.
By their numbers in this assay, from the lowest: compound 3; then compounds 2 and 1 (each within the scatter of the next).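

The group on the sulfur does matter in this assay, since 3,5-dimethylphenyl gives a number 11.6 percentage points lower from compound 2 to compound 3 (beyond the scatter) and also a number 13.6 percentage points lower from compound 1 to compound 3 (beyond the scatter), whereas phenethyl and 3-fluorophenyl could not be told apart. Compound 2 and compound 3 have the same atoms, and the leaving and entering groups match in heavy atoms and in their one aromatic ring, so these counts do not separate the two results. An aromatic ring on the sulfur does not by itself hold the number either, as compound 1 and compound 3 both carry one, and no measurement at hand bears on why the number fell.

From the compounds shown here alone, whether both methyl groups are needed for the lower number remains open, and 3-methylphenyl on the sulfur would address that. Also open, going by these compounds, is how an amine or a carboxylic acid on that ring, or a longer chain on the sulfur, would read.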